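This account rests on a few compounds, and the source may have more. Where it says the series, first, only, none or still open, it means among the compounds named here.

Measured compounds:
Compound 1, `CCCCNc1nc(N)nc2ccn(Cc3ccccc3)c12` — in an assay on HEK293 cells for agonist activity at Toll-like receptor 8 (Homo sapiens), read by a luciferase reporter, with a stated time of 6 h (on this read-out higher numbers stand for an effect only at larger amounts of compound and lower numbers for an effect already at smaller amounts), compound 1 gives > 25 uM, which is a limit of the assay rather than a number.
Compound 2, `CCCCNc1nc(N)nc2ccn(CCCc3ccccc3)c12` — in this assay compound 2 gives 3.78 uM.

Among the measured compounds shown here, compound 2 therefore stands as the only compound with an actual number in this assay; the other value shown is the limit of > 25 uM in this assay, at which 1 of the 2 values shown sits. The piece now follows the step to compound 3, `CCCCNc1nc(N)nc2ccn(CC(=O)NC)c12`. The change is methylcarbamoyl in place of phenethyl on a saturated chain carbon bound to an aromatic nitrogen. For the measured compounds named here, only one measured step touches the same place: an at least 6.6-fold lower number from compound 1 to compound 2 (0.82 log units; beyond the scatter), in which the phenethyl group lowered the number compared with phenyl. Compound 3 goes the other way, taking the phenethyl group away altogether and putting a small methylcarbamoyl group in its stead. On that single step, the expectation is that the number rises again, so that compound 3 is estimated to need more compound than compound 2, with a real chance that this assay reports only a limit. Compound 3 is expected to give about 15 uM in this assay, estimated within 3 uM to 50 uM, which means an expected step of a 4.0-fold higher number from compound 2 to compound 3 (0.60 log units; beyond the scatter).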

Compound 3, minimum effective concentration: > 25 uM
Compound 3 ended at the assay's limit; the forecaster's own chance of this, stated with the estimate: 40%; middle value at least 1.6-fold (0.22 log units) from the limit.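

The step back from phenethyl to methylcarbamoyl gives an at least 6.6-fold higher number from compound 2 to compound 3 (0.82 log units; beyond the scatter), so the measurable effect seen in compound 2 does not survive this exchange on the saturated chain carbon bound to the aromatic nitrogen. Until now, the position had been probed only with groups carrying a six-membered aromatic ring, whereas methylcarbamoyl has no ring, fewer heavy atoms, and brings in a hydrogen-bond donor and acceptor. Compound 2 remains the only compound here with an actual number in this assay, and the other two stop at a limit of the assay, so the step between those two cannot be read: the limit of > 25 uM in this assay, at which 2 of the 3 values shown sit.

The compounds shown leave open which part of the exchange matters, the loss of the ring, the smaller size or the arrival of the amide, as all of these change together from compound 2 to compound 3. A plain hexyl chain, a longer chain ending in phenyl, or a chain ending in an amine or a carboxylic acid would help pull these apart, and would show whether the number can fall further at this position.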